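The source may report more compounds than this note shows. Statements on the series, on what has been measured and on what is new or still open speak of the compounds shown alone.

Measured so far:
- compound 1 `COC(=O)[C@@]1(C)CC[C@@H]2C3=C1CC[C@@H](C)[C@]3(C)C[C@@H]1c3cc(C)ccc3N[C@H]21` — 32000 nM
- compound 2 `COC(=O)[C@@]1(C)CC[C@@H]2C3=C1CC[C@@H](C)[C@]3(C)C[C@@H]1c3cc(Br)ccc3N[C@H]21` — 55000 nM

Both numbers come from a functional assay on WiDr cells (Homo sapiens) for inhibition, read by sulforhodamine B assay, with a stated time of 48 h; on this read-out lower numbers stand for stronger inhibition of growth and higher numbers for weaker inhibition of growth. Compound 2 stands at the highest of the two numbers; its nearest neighbour is compound 1, and the step of a 1.7-fold higher number from compound 1 to compound 2 (0.24 log units; within the scatter) lies within the scatter, so the two compounds cannot be ordered against each other on these data.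

Compound 3 `COC(=O)[C@@]1(C)CC[C@@H]2C3=C1CC[C@@H](C)[C@]3(C)C[C@@H]1c3cc(Cl)ccc3N[C@H]21` differs from compound 2 in one place: chloro in place of bromo on an aromatic carbon, on an aromatic carbon of a six-membered aromatic ring of carbon only, part of a fused system of five rings. For the measured compounds named here, the only measured step that bears on this position is a 1.7-fold higher number from compound 1 to compound 2 (0.24 log units; within the scatter), an exchange of methyl for bromo that stayed within the scatter. A second halogen exchange at the same carbon is therefore expected to give no step beyond the scatter in this assay, with a 1.2-fold lower number from compound 2 to compound 3 (0.09 log units; within the scatter) as the expected movement. Compound 3 is estimated at 45000 nM, within the range 20000 nM to 100000 nM.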

Compound 3, concentration for 50% growth inhibition: 48000 nM
For compound 3 the middle estimate is 1.1-fold (0.03 log units) below the measured one; measured number inside the range.
By their numbers in this assay, from the lowest: compounds 1, 3 and 2 (each within the scatter of the next).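

In this assay this aromatic carbon now carries three groups, and the exchange of one halogen for the other gives a 1.1-fold lower number from compound 2 to compound 3 (0.06 log units; within the scatter) with no change that can be read. The exchange of methyl for chloro gives a 1.5-fold higher number from compound 1 to compound 3 (0.18 log units; within the scatter) and also stays within the scatter. Together with the earlier exchange of methyl for bromo, this means that all three pairs at this position lie within the scatter, so compounds 1, 2 and 3 cannot be ordered, and no evidence bears on this result.

From the compounds shown here alone, whether a group of another kind at this carbon, such as an amine, a carboxylic acid or a longer chain, would give a step beyond the scatter remains open. Also open, going by these compounds, is whether a change elsewhere on the shared core, such as a carboxylic acid in place of the methyl ester, would move the number.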